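The compounds below may be only part of what the source reports. "The series", "measured", "known", "first", "only" and "open" are said of these compounds alone.

Measured compounds:
compound 1, `CCCCOC(=O)Nc1cc2nc(C3CCCCC3)[nH]c2cc1N(CC)CCN(C)C`
compound 2, `CCCNC(=O)Nc1cc2nc(C3CCCCC3)[nH]c2cc1N(CC)CC`
compound 3, `CCCCOC(=O)Nc1cc2nc(C3CCCCC3)[nH]c2cc1N(C)C`

In an ADME assay on Vero cells (Chlorocebus sabaeus) for cytotoxicity, read by resazurin assay, with a stated time of 3 days (on this read-out higher numbers stand for weaker inhibition and lower numbers for stronger inhibition), compound 1 gives > 100 ug/mL, which is a limit of the assay rather than a number. Compound 2 gives > 100 ug/mL in this assay, again a limit. Compound 3 gives > 100 ug/mL in this assay, also a limit. Compound 3 therefore stands at the same limit as the two other compounds, and no order among the three can be read from these values. Within the data shown here, the one measured step, a step that the two limits leave unreadable from compound 1 to compound 3, is unreadable, since both of its ends sit at the limit that the limit of > 100 ug/mL in this assay, at which 3 of the 3 values shown sit, records.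

Compound 4, `CCCCOC(=O)Nc1cc2nc(C3CCCCC3)[nH]c2cc1N(CC)CC`, has not yet been measured in this assay. It differs from compound 3 by diethylamino in place of dimethylamino on an aromatic carbon. Among the measured compounds shown here, no measured step speaks directly to this change, and the only step that exists hides its own size, so nothing beyond the scatter can be predicted from it. Because every value shown sits at the limit recorded in the limit of > 100 ug/mL in this assay, at which 3 of the 3 values shown sit, compound 4 is expected to sit there too, and a step that the limit leaves unreadable from compound 3 to compound 4 is the expected step, of no readable size. Compound 4 is therefore estimated at 150 ug/mL, within 80 ug/mL to 300 ug/mL.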

Compound 4, half-maximal inhibitory concentration: > 100 ug/mL
Compound 4 gave a limit, no number; the forecaster's own chance of this, stated with the estimate: 85%; the middle value lies beyond the limit too.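

No new step can be read from compound 4, since its comparisons with compound 1, compound 2 and compound 3 all end at a limit of the assay rather than at a number: the limit of > 100 ug/mL in this assay, at which 4 of the 4 values shown sit. The compounds shown leave open, in this assay and for all four alike, what actual value each would give and whether changing any group shifts it.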